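This account rests on a few compounds, and the source may have more. Where it says the series, first, only, none or still open, it means among the compounds named here.

Measured in a physicochemical assay for solubility, at pH 7.4; on this read-out lower numbers stand for lower solubility and higher numbers for higher solubility:
- compound 1 `Cc1cc(NC(=O)Nc2ccccc2N)c2ccccc2n1` gives 51800 nM
- compound 2 `Cc1cc(NC(=O)Nc2ccc(F)cc2)c2ccccc2n1` gives 3700 nM
- compound 3 `Cc1cc(NC(=O)Nc2ncccc2C)c2ccccc2n1` gives 1300 nM

Compound 1 has the highest of these three numbers, and the other two compounds lie well under it. The next compound to consider is compound 4 `Cc1cc(NC(=O)Nc2ccccc2[N+](=O)[O-])c2ccccc2n1`, which has not yet been measured. It keeps the rest of compound 1 and changes a single group: nitro in place of amino on an aromatic carbon, ortho to a large group (nitro in place of amino on an aromatic carbon).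

Within the data shown here, two measured steps bear on this change, as each removes the 2-aminophenyl group of compound 1. One puts 4-fluorophenyl in its place, giving a 14-fold lower number from compound 1 to compound 2 (1.15 log units; beyond the scatter), a large step. The other puts 3-methylpyridin-2-yl in its place, giving a 40-fold lower number from compound 1 to compound 3 (1.60 log units; beyond the scatter), also a large step. The two replacements differ only modestly from each other, with a 2.8-fold lower number from compound 2 to compound 3 (0.45 log units; beyond the scatter). Among the measured compounds shown here, neither step is a direct test, since no measured compound keeps this ring and changes only the amino group. Compound 4 does lose the amino group, so a large step to a lower number is expected in this assay, though with real uncertainty in its size.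

For compound 4 the expected value is 5000 nM, with an estimated range from 1500 nM to 18000 nM. This estimate means a 10-fold lower number from compound 1 to compound 4 (1.02 log units; beyond the scatter).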

Compound 4, solubility: 200 nM
For compound 4 the middle estimate is 25-fold (1.40 log units) above the measured one; measured number below the stated range.
By their numbers in this assay, from the lowest: compound 4; then compound 3; then compound 2; then compound 1.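

In this assay, nitro in place of amino on an aromatic carbon, ortho to a large group, gives a 260-fold lower number from compound 1 to compound 4 (2.41 log units; beyond the scatter) and leaves the rest of the molecule untouched. Among these compounds, this is the first reading of a change to this one group alone, as compound 2 and compound 3 each replaced the whole 2-aminophenyl group, and the step is larger than either of the steps from compound 1 to those two compounds, so swapping only the group at this place can shift the number further than those wider replacements did. What lies behind the size of this step cannot be told, as no measurement of any property of these compounds is available to explain it.

With only amino and nitro seen at this place, the compounds shown leave open how much of the step comes from losing amino and how much from bringing in nitro, a question that plain hydrogen, a methyl, a methoxy or a carboxylic acid at the same carbon would help to settle. They also leave open whether the same swap would give a step of similar size at another carbon of this ring, or on a core with a different group in place of the methyl.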